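Shortening the selenocyanate chain of compound 2

This account rests on a few compounds, and the source may have more. Where it says the series, first, only, none or still open, it means among the compounds named here.

Of the compounds shown here, three sharing the same quinazoline-based core have been measured in a functional assay on A549 cells (Homo sapiens) for inhibition, read by MTT assay, with a stated time of 48 h; on this read-out lower numbers stand for stronger inhibition and higher numbers for weaker inhibition. Compound 1 `Cc1nc(N(C)c2ccc([Se]C#N)c(Cl)c2)c2ccccc2n1` gives 7 nM, and compound 3 `C[Se]c1ccc(N(C)c2nc(C3CC3)nc3ccccc23)cc1` gives 13 nM. Compound 2 `COc1ccc(N(C)c2nc(C)nc3ccccc23)cc1C(=O)OCCCCC[Se]C#N` gives 592 nM, the highest of the three numbers; its nearest neighbour is compound 3, whose number is far lower, and the gap to compound 1 is wider still, both gaps lying beyond the usual scatter. Compound 2 thus stands as the weakest inhibitor of the three in this assay.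

Compound 4 `COc1ccc(N(C)c2nc(C)nc3ccccc23)cc1C(=O)OCCCC[Se]C#N` has not yet been measured. It differs from compound 2 by a group of 3 heavy atoms (1 carbon, 1 nitrogen, 1 selenium; no ring) in place of a group of 4 heavy atoms (2 carbon, 1 nitrogen, 1 selenium; no ring), on a saturated chain carbon, four bonds along the chain from an oxygen next to a carbonyl group. The ester, the methoxy group and the core are unchanged; only the chain that carries the selenocyanate is altered. Going by the values given here, no pair of measured compounds differing in just this way is available, so the size of the step cannot be read from the data.

The account therefore rests on expectation alone. Since the change is confined to the chain, the step from compound 2 to compound 4 is expected to be small, likely within the scatter, and is estimated as a 1.1-fold lower number from compound 2 to compound 4 (0.03 log units; within the scatter). Compound 4 is thus expected to give about 550 nM in this assay, with a plausible range from 200 nM to 1600 nM.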

Compound 4, half-maximal inhibitory concentration: 155 nM
Beside the measured number, compound 4's estimate is 3.5-fold (0.55 log units) above it; measured number below the stated range.
By their numbers in this assay, from the lowest: compounds 1 and 3 (each within the scatter of the next); then compound 4; then compound 2.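

In this assay, the chain carrying the selenocyanate proves able to shift the number: a 3.8-fold lower number from compound 2 to compound 4 (0.58 log units; beyond the scatter), a modest step for a group of 3 heavy atoms in place of a group of 4 heavy atoms, on a saturated chain carbon, four bonds along the chain from an oxygen next to a carbonyl group. This is the only single change that can be read among the compounds shown, as the earlier compounds differ from one another in more than one place and so gave no measure of what this chain contributes. No measurement at hand bears on why the number moves with this change.

Going by these compounds alone, one step joins only two chain lengths, so it remains open whether a still shorter chain would lower the number further or a longer chain would raise it. Also open, going by these compounds, is whether the same step would appear with a methyl selenide or a carboxylic acid at the end of the chain in place of the selenocyanate, or with the cyclopropyl group of compound 3 on the shared core.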